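Benzyl for formyl on the ring nitrogen: what to expect

The source may hold more compounds than are shown below. What is called first, only, known or untested is meant among the compounds shown, and "the series" means these compounds.

Of the compounds shown here, two have been tested in a functional assay on the whole organism with Rattus norvegicus as the target, at a dose of 40 mg/kg by the intraperitoneal route; on this read-out lower numbers stand for less inhibition and higher numbers for more inhibition at the one dose given (going by the name of the read-out). Compound 1 `Cc1nc2c(OCc3ccsc3)cccn2c1N` carries a free amine on its core; in this assay compound 1 gives 52%. Compound 2 `Cc1nc2c(OCc3ccccc3)cccn2c1NC=O` carries a formyl group on that nitrogen and a benzyloxy group in place of the thienylmethoxy group of compound 1; in this assay compound 2 gives 49%. Among the measured compounds shown here, the two numbers sit close together, their gap within the usual scatter, so nothing separates compound 1 from compound 2 on this read-out, and no step between measured compounds that differ in one place exists to guide the next move.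

The next compound, compound 3 `Cc1nc2c(OCc3ccccc3)cccn2c1NCc1ccccc1`, keeps the core and the benzyloxy group of compound 2 and differs from it only at the nitrogen: benzyl in place of formyl on a nitrogen on an aromatic ring. For the measured compounds named here, no measured pair shows this kind of exchange, so the direction is open. On the numbers of compound 1 and compound 2 alone, a modest fall is the expectation, and the step from compound 2 to compound 3 is estimated at a number 9 percentage points lower from compound 2 to compound 3 (within the scatter) in this assay. Compound 3 is therefore expected to give about 40% in this assay, with a range from 15% to 65%.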

Compound 3, a percentage reported as inhibition, in the whole organism at one dose (the size of the read-out at that dose, not a potency): 48%
For compound 3 the middle estimate is 8 percentage points below the measured one, and the stated range covers the measured number.
By their numbers in this assay, from the lowest: compounds 3, 2 and 1 (each within the scatter of the next).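

Among the compounds shown here, the exchange of formyl for benzyl on a nitrogen on an aromatic ring gives the first reading at this position with the rest of the molecule held constant: in this assay the step reads a number 1 percentage points lower from compound 2 to compound 3 (within the scatter). The entering benzyl has 7 heavy atoms and a six-membered aromatic ring of carbon only, while the leaving formyl has 2 heavy atoms and 1 hydrogen-bond acceptor, yet this large difference in the substituent does not separate the two compounds at the one dose given. This position therefore accepts either group in this assay with no shift beyond the scatter, and nothing available bears on why the two read alike.

The free amine of compound 1 has no partner carrying the benzyloxy group among the compounds shown, so what any group on this nitrogen adds over the free amine remains open. Also open, on these data alone, is how an acetyl group, a phenethyl group or a chain ending in a carboxylic acid on the same nitrogen would read, and whether a single-dose read-out would hide differences that a range of doses could show.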